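Adding a methyl to the piperazine of compound 3

The source may hold more compounds than are shown below. What is called first, only, known or untested is meant among the compounds shown, and "the series" means these compounds.

Compound 1 `CCNC(=O)c1nnn(-c2cc(C(C)C)c(O)cc2O)c1-c1ccc(CN2CCCC(O)C2)cc1`: 62 nM
Compound 2 `CCNC(=O)c1nnn(-c2cc(C(C)C)c(O)cc2O)c1-c1ccc(CN2CCC[C@@H](O)C2)cc1`: 52 nM
Compound 3 `CCNC(=O)c1nnn(-c2cc(C(C)C)c(O)cc2O)c1-c1ccc(CN2CCNCC2)cc1`: 250 nM

In a functional assay on NCI-H460 cells (Homo sapiens) for inhibition, read by sulforhodamine B assay, with a stated time of 72 h (on this read-out higher numbers stand for weaker inhibition and lower numbers for stronger inhibition), compound 3 gives 250 nM, the highest number of the three and so the weakest inhibition here. Compound 4 `CCNC(=O)c1nnn(-c2cc(C(C)C)c(O)cc2O)c1-c1ccc(CN2CCN(C)CC2)cc1` differs from it in one place: methyl in place of hydrogen on an amine nitrogen in a ring. This is methyl in place of hydrogen on an amine nitrogen in a ring.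

Among the measured compounds shown here, no measured step makes this exact change. The closest evidence comes from the same site, where piperazin-1-yl replaced 3-hydroxypiperidin-1-yl: a 4.0-fold higher number from compound 1 to compound 3 (0.61 log units; beyond the scatter) and a 4.8-fold higher number from compound 2 to compound 3 (0.68 log units; beyond the scatter). Both steps are modest but beyond the scatter, so the group at this site can move the number. The step of a 1.2-fold lower number from compound 1 to compound 2 (0.08 log units; within the scatter) concerns only the drawn configuration the fact that one of compounds 1 and 2 is drawn with a defined configuration and the other without, at the place where they differ and does not bear on the new change.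

Adding a methyl alters less than replacing a whole ring, so a smaller step is expected here. The step expected is a 1.4-fold lower number from compound 3 to compound 4 (0.14 log units; within the scatter), which would not go beyond the scatter. Compound 4 is estimated at 180 nM, with an expected range of 70 nM to 450 nM.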

Compound 4, half-maximal inhibitory concentration: 47 nM
Beside the measured number, compound 4's estimate is 3.8-fold (0.58 log units) above it, and the stated range ends above it.
By their numbers in this assay, from the lowest: compounds 4, 2 and 1 (each within the scatter of the next); then compound 3.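

In this assay, the amine nitrogen of the piperazine proves to be a sensitive place: a single added methyl gives a 5.3-fold lower number from compound 3 to compound 4 (0.73 log units; beyond the scatter) and so removes the loss seen with the unsubstituted ring. The 4-methylpiperazin-1-yl group stands level with the 3-hydroxypiperidin-1-yl group, at a 1.1-fold lower number from compound 2 to compound 4 (0.04 log units; within the scatter) and a 1.3-fold lower number from compound 1 to compound 4 (0.12 log units; within the scatter), so among these compounds the weaker number belongs to the piperazin-1-yl compound alone and not to every piperazine. Among the compounds shown here, nothing available explains the effect of the methyl, as the only evidence concerns how a configuration is drawn and does not bear on this change.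

As far as these compounds go, whether the gain stops at methyl remains open. An ethyl, an isopropyl or an acetyl group on the same nitrogen would show how the number responds to something larger than one carbon.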